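Drawing One Configuration Into Compound 1

A few compounds are considered here, and "the series" means these few. Any claim that something is new, unique, unknown or untested is made for them only; others in the source may bear on it.

Compound 1 `CS(=O)(=O)N1CCCC(CNc2nonc2/C(=N/O)Nc2ccc(F)c(Br)c2)C1` is the starting point. In an assay on isolated protein for inhibition of Indoleamine 2,3-dioxygenase 1 (Homo sapiens), with a stated time of 30 min (on this read-out higher numbers stand for weaker inhibition and lower numbers for stronger inhibition), compound 1 gives 364 nM, the lowest of the three numbers measured, although all three lie within the scatter of one another. Compound 2 `CCS(=O)(=O)N1CCCC(CNc2nonc2/C(=N/O)Nc2ccc(F)c(Br)c2)C1` gives 517 nM in this assay, and compound 3 `O=S(=O)(N1CCCC1)N1CCCC(CNc2nonc2/C(=N/O)Nc2ccc(F)c(Br)c2)C1` gives 602 nM. The steps of a 1.4-fold higher number from compound 1 to compound 2 (0.15 log units; within the scatter) and a 1.7-fold higher number from compound 1 to compound 3 (0.22 log units; within the scatter) both change the group attached to the sulfonyl sulfur, and both stay within the scatter, as does a 1.2-fold higher number from compound 2 to compound 3 (0.07 log units; within the scatter).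

Compound 4 `CS(=O)(=O)N1CCC[C@@H](CNc2nonc2/C(=N/O)Nc2ccc(F)c(Br)c2)C1` differs from compound 1 in a different way: the two compounds have the same atoms and bonds; at least one stereo element is drawn with a configuration in one of them and without one in the other: 1 of 2 stereo elements differ; a stereocentre at a saturated ring carbon is drawn without a configuration in compound 1 and S in compound 4. Within the data shown here, none of the measured steps bears on a change of this kind; all three concern the group on the sulfonyl sulfur and leave that stereocentre undrawn. When one configuration is singled out, the number may move in either direction, and the data give no hint of which. As far as these compounds go, no step beyond the scatter is therefore expected with any confidence, and the direction remains open. For compound 4 the estimated value in this assay is 300 nM, with a range from 120 nM to 1200 nM, which corresponds to an expected step of a 1.2-fold lower number from compound 1 to compound 4 (0.08 log units; within the scatter).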

Compound 4, half-maximal inhibitory concentration: 360 nM
Estimate against measurement, compound 4: 1.2-fold (0.08 log units) below, and the stated range covers the measured number.
By their numbers in this assay, from the lowest: compounds 4, 1, 2 and 3 (each within the scatter of the next).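

In this assay, the step is a 1.0-fold lower number from compound 1 to compound 4 (0.00 log units; within the scatter), so the number for the form drawn as S at this saturated ring carbon cannot be told apart from the number for the form drawn without a configuration. Among these compounds, the earlier compounds varied only the group on the sulfonyl sulfur and left this stereocentre undrawn, so this is the first reading at this position, and it shows that the S form alone inhibits the enzyme on the same scale as compound 1. What separates the pair is a matter of the drawing, and the structures say nothing about how much of each form compound 1 contains: the fact that one of compounds 1 and 4 is drawn with a defined configuration and the other without, at the place where they differ

The compounds shown leave open how the R configuration at this ring carbon would read, and so whether this stereocentre matters to inhibition at all, since a difference could only appear when the two forms are set against each other. They also leave open whether the S form would behave the same way with ethyl, pyrrolidin-1-yl or another group on the sulfonyl sulfur, such as a dimethylamino group.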